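Four Chalcone-Like Compounds at the Assay Limit

The compounds below may be only part of what the source reports. "The series", "measured", "known", "first", "only" and "open" are said of these compounds alone.

Values from a functional assay on HT-29 cells (Homo sapiens) for antiproliferative activity, read by MTT assay, with a stated time of 24 h (a higher number here means a weaker inhibitor, a lower number a stronger inhibitor), follow, and each one is a limit:
- Compound 1 (`COc1ccc(C(=O)/C=C/c2cc(OC)c(OC)c(OC)c2)c2c1C=CC(C)(C)O2`) gives > 10000 nM (a limit)
- Compound 2 (`COc1ccc(/C=C/C(=O)c2ccc(OC)c3c2OC(C)(C)C=C3)c(F)c1`) gives > 10000 nM (a limit)
- Compound 3 (`COc1cc(OC)c(OC)cc1/C=C/C(=O)c1ccc(OC)c2c1OC(C)(C)C=C2`) gives > 10000 nM (a limit)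

Compound 2 therefore has no exact number to start from, and the same is true of the whole set (the limit of > 10000 nM in this assay, at which 3 of the 3 values shown sit). Compound 4 (`COc1ccc(C(=O)/C=C/c2ccc(Br)cc2)c2c1C=CC(C)(C)O2`) differs from compound 2 by one change (4-bromophenyl in place of 2-fluoro-4-methoxyphenyl on a double-bonded chain carbon bound to a double-bonded chain carbon): 4-bromophenyl in place of 2-fluoro-4-methoxyphenyl on a double-bonded chain carbon bound to a double-bonded chain carbon. Among the compounds with values here, no measured pair shows what such a change does. Compound 3, with another group at this place, also gives the limit > 10000 nM and no number. No step beyond the usual scatter is therefore expected, in either direction, and compound 4 may well stay at the limit. The expected change is a number no higher from compound 2 to compound 4 (the limit leaves the size open) on this estimate. In this assay the estimated value for compound 4 is 10000 nM and it is expected to lie from 4000 nM to 25000 nM in most repeats.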

Compound 4, half-maximal inhibitory concentration: > 10000 nM
Compound 4 ended at the assay's limit (the forecaster's own chance of this, stated with the estimate: 60%); the middle value lies on the limit itself.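

No step can be read from compound 2 to compound 4, as each value is a limit and not a number: the limit of > 10000 nM in this assay, at which 4 of the 4 values shown sit.

The compounds shown leave open whether any other group at this place would give a measurable number.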